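A few compounds are considered here, and "the series" means these few. Any claim that something is new, unique, unknown or untested is made for them only; others in the source may bear on it.

In a functional assay on DU-145 cells (Homo sapiens) for cytotoxicity, read by trypan blue exclusion, with a stated time of 96 h (a lower number here means a stronger inhibitor, a higher number a weaker inhibitor), compound 1 (`COc1ccc(CS(=O)(=O)/C=C/c2ccccc2OC)cc1N`) gives 7500 nM and compound 2 (`COC(=O)CNc1cc(CS(=O)(=O)/C=C/c2c(OC)cc(OC)cc2OC)ccc1OC`) gives 100 nM as the lower of the two numbers, a gap beyond the scatter. Compound 3 (`COC(=O)C(F)(F)Nc1cc(CS(=O)(=O)/C=C/c2c(OC)cc(OC)cc2OC)ccc1OC`) carries difluoro(methoxycarbonyl)methyl in place of the (methoxycarbonyl)methyl of compound 2 on a nitrogen on an aromatic ring (difluoro(methoxycarbonyl)methyl in place of (methoxycarbonyl)methyl on a nitrogen on an aromatic ring). Among the measured compounds shown here, no measured step covers this change, so in this assay either no move beyond the scatter or a small rise in the number is expected. The estimated step is a 1.5-fold higher number from compound 2 to compound 3 (0.18 log units; within the scatter) as a working expectation. For compound 3 the expected value is 150 nM with an estimated range of 40 nM to 600 nM for the measurement.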

Compound 3, half-maximal inhibitory concentration: 250 nM
Estimate against measurement, compound 3: 1.7-fold (0.22 log units) below; the measured number falls inside the stated range.
By their numbers in this assay, from the lowest: compound 2; then compound 3; then compound 1.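

In this assay the series now has its first single-place comparison: a 2.5-fold higher number from compound 2 to compound 3 (0.40 log units; beyond the scatter) shows that difluoro(methoxycarbonyl)methyl in place of (methoxycarbonyl)methyl on a nitrogen on an aromatic ring weakens inhibition modestly. The position therefore responds to this change, yet compound 3 keeps a measurable inhibitory value. No supporting data bear on the reason for this step. Still open, on these data alone, is how a carboxylic acid in place of the methyl ester, or a longer chain on this nitrogen, would read. As far as these compounds go, whether the step carries over to another core also remains open.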